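Cytotoxicity notes: amide-linked variants of compound 1

The source may hold more compounds than are shown below. What is called first, only, known or untested is meant among the compounds shown, and "the series" means these compounds.

Measured so far:
- compound 1 `Nc1nn(Cc2cn(-c3ccc(O)c([N+](=O)[O-])c3)nn2)c2nc(-c3ccccc3)cc(C(F)(F)F)c12`: 36.3 ug/mL
- compound 2 `Cc1ccc(NC(=O)Cn2cc(Cn3nc(N)c4c(C(F)(F)F)cc(-c5ccccc5)nc43)nn2)cc1`: 41.5 ug/mL

In a functional assay on THP-1 cells (Homo sapiens) for cytotoxicity, read by MTT assay, with a stated time of 24 h (a lower number here means a stronger inhibitor, a higher number a weaker inhibitor), compound 1 gives the lowest of the two numbers; its nearest neighbour is compound 2, separated by a 1.1-fold higher number from compound 1 to compound 2 (0.06 log units; within the scatter), so the two are not distinguishable. Compound 3 `Nc1nn(Cc2cn(CC(=O)NC3CCCCC3)nn2)c2nc(-c3ccccc3)cc(C(F)(F)F)c12` is not yet measured. Relative to compound 1 the change is (cyclohexylcarbamoyl)methyl in place of 4-hydroxy-3-nitrophenyl on an aromatic nitrogen. For the measured compounds named here, the only step that bears on this is the one from compound 1 to compound 2, where the same 4-hydroxy-3-nitrophenyl on the aromatic nitrogen gave way to a carbamoylmethyl group carrying a 4-methylphenyl; that step was a 1.1-fold higher number from compound 1 to compound 2 (0.06 log units; within the scatter), within the scatter. Here a cyclohexyl replaces the 4-methylphenyl on the amide, so no step beyond the scatter is expected in this assay, in either direction. Compound 3 is therefore estimated at 40 ug/mL, with a range of 20 ug/mL to 80 ug/mL. The expected step of a 1.1-fold higher number from compound 1 to compound 3 (0.04 log units; within the scatter) lies within the scatter.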

Compound 3, half-maximal inhibitory concentration: 64.8 ug/mL
The estimate for compound 3 lay 1.6-fold (0.21 log units) below the measured number; the range from low to high includes it.
By their numbers in this assay, from the lowest: compounds 1, 2 and 3 (each within the scatter of the next).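

In this assay, cyclohexyl in place of 4-methylphenyl on the amide-type nitrogen gives no step beyond the scatter (a 1.6-fold higher number from compound 2 to compound 3 (0.19 log units; within the scatter)), so a non-aromatic ring of carbon only and an aromatic one cannot be told apart on this amide. The same holds on the aromatic nitrogen of the five-membered ring, where (cyclohexylcarbamoyl)methyl stands against 4-hydroxy-3-nitrophenyl (a 1.8-fold higher number from compound 1 to compound 3 (0.25 log units; within the scatter)), so this position has now carried substituents with and without any aromatic ring, with no step beyond the scatter. No measurement bears on what lies behind these numbers. As far as these compounds go, it remains open whether a piperidine or a carboxylic acid on the amide would move the number beyond the scatter. From the compounds shown here alone, a longer chain between the carbonyl and the aromatic nitrogen is equally open.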